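A few compounds are considered here, and "the series" means these few. Any claim that something is new, unique, unknown or untested is made for them only; others in the source may bear on it.

Compounds measured so far:
compound 1, `COc1ccc2nc(C)cc(OCC(=O)Nc3cc(C)c(OC)c(C)c3)c2c1`, 4.99;
compound 2, `COc1ccc2nc(C)cc(OCC(=O)Nc3cc(C)c(F)c(C)c3)c2c1`, 5.5.

In a physicochemical assay for lipophilicity, read by HPLC, in phosphate buffer, measured as chromatographic lipophilicity, at pH 7.4 (a lower number here means a more polar compound, a higher number a more lipophilic compound), compound 2 stands highest of the two numbers; its nearest neighbour is compound 1, and the step of a number 0.51 log units higher from compound 1 to compound 2 (beyond the scatter) runs beyond the scatter. Among the compounds with values here, that step, fluoro in place of methoxy on an aromatic carbon, is the only measured step in this set.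

Compound 3, `COc1ccc2nc(C)cc(OCC(=O)NC3CONC3=O)c2c1`, has not yet been measured in this assay. Compared with compound 2 it carries a group of 6 heavy atoms (3 carbon, 1 nitrogen, 2 oxygen; one five-membered non-aromatic ring with 2 hetero atoms) in place of a group of 9 heavy atoms (8 carbon, 1 fluorine; one six-membered aromatic ring of carbon only), on an amide-type nitrogen.

Within the data shown here, no measured step bears directly on this change: the one step recorded, from compound 1 to compound 2, swaps one substituent on the aromatic ring for another and leaves the ring itself in place, whereas here the whole 4-fluoro-3,5-dimethylphenyl group leaves and a five-membered non-aromatic ring with two hetero atoms, one hydrogen-bond donor and two hydrogen-bond acceptors enters on the amide-type nitrogen. Because the number in this assay rose by a number 0.51 log units higher from compound 1 to compound 2 (beyond the scatter) when a methoxy gave way to a fluoro, and the present change removes a far larger carbon-rich group, the expected step of a number 3.00 log units lower from compound 2 to compound 3 (beyond the scatter) is large and downward, well beyond the scatter. Compound 3 is therefore estimated at 2.5, within a range from 1.8 to 3.3.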

Compound 3, distribution coefficient: 0.79
Estimate against measurement, compound 3: 1.71 log units above; the whole stated range lies above it.
By their numbers in this assay, from the lowest: compound 3; then compound 1; then compound 2.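

The exchange at the amide-type nitrogen moves the number far more than the earlier change on the aromatic ring. In this assay, replacing the 4-fluoro-3,5-dimethylphenyl group with the five-membered non-aromatic ring gives a number 4.71 log units lower from compound 2 to compound 3 (beyond the scatter), a large step, whereas the fluoro-for-methoxy swap gave only the modest a number 0.51 log units higher from compound 1 to compound 2 (beyond the scatter). The result shows that, with the core held constant, the group on this nitrogen can take the reading from the top of the set down to the 0.79 of compound 3, but nothing available accounts for the size of this drop.

The exchange alters several things at once: the aromatic ring leaves, the heavy-atom count falls, and hetero atoms, a hydrogen-bond donor and hydrogen-bond acceptors enter, so the compounds shown cannot assign the step to any one of these. They also leave open where a cyclohexyl ring, a morpholine ring or a short carboxylic acid chain on the same nitrogen would fall in this assay, and thus whether the number changes gradually or abruptly across this range of groups.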